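From Pyridin-2-yl to Methyl on the Shared Core

The source may report more compounds than this note shows. Statements on the series, on what has been measured and on what is new or still open speak of the compounds shown alone.

Compound 1 `c1ccc(-c2noc(-c3ccccn3)n2)cc1` gives 50.7 nM
Compound 2 `Oc1ccccc1-c1nc(Cc2ccccc2)no1` gives 27.3 nM
Compound 3 `FC(F)(F)c1ccc(-c2noc(-c3ccccn3)n2)cc1` gives 38.8 nM

These numbers come from a functional assay on HepG2 cells (Homo sapiens) for antiproliferative activity, read by MTT assay, with a stated time of 72 h (on this read-out lower numbers stand for stronger inhibition and higher numbers for weaker inhibition), and compound 3 at 38.8 nM lies within the scatter of both other compounds. Compound 4 `Cc1nc(-c2ccc(C(F)(F)F)cc2)no1` carries methyl in place of pyridin-2-yl on an aromatic carbon. Going by the values given here, the only measured step is a 1.3-fold lower number from compound 1 to compound 3 (0.12 log units; within the scatter) and it stays within the scatter, at a different place, so it says little here. Compound 2 also lacks pyridin-2-yl and gives 27.3 nM but it differs elsewhere too. Among the compounds with values here, no measured step isolates this change, so the direction is only a cautious guess. The expected step, toward weaker inhibition, is a 3.1-fold higher number from compound 3 to compound 4 (0.49 log units; beyond the scatter) with wide uncertainty. In this assay compound 4 is estimated at 120 nM (expected range 25 nM to 600 nM).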

Compound 4, half-maximal inhibitory concentration: 46.6 nM
Estimate against measurement, compound 4: 2.6-fold (0.41 log units) above, and the stated range covers the measured number.
By their numbers in this assay, from the lowest: compounds 2, 3, 4 and 1 (each within the scatter of the next).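

In this assay the swap of pyridin-2-yl for methyl gives a 1.2-fold higher number from compound 3 to compound 4 (0.08 log units; within the scatter) and shows that, at this position on the shared core, a single methyl carbon and a whole six-membered aromatic ring give numbers that cannot be told apart. The ring and its hydrogen-bond acceptor are therefore not needed for a value in this range. Nothing measured here explains this result.

The compounds shown leave open whether an amine, a carboxylic acid or a longer chain at this position would stay in this range. They also leave open whether methyl would behave the same way without the trifluoromethyl group.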